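This account rests on a few compounds, and the source may have more. Where it says the series, first, only, none or still open, it means among the compounds named here.

Of the compounds shown here, two with a shared core have been measured in a functional assay on SK-BR-3 cells (Homo sapiens) for antiproliferative activity, read by CCK-8 assay, with a stated time of 72 h; a higher number here means a weaker inhibitor, a lower number a stronger inhibitor. There, compound 1 `Cc1cc(Nc2cc(N3CCN(C)CC3)nc(Nc3ccc([N+](=O)[O-])cc3)n2)n[nH]1` gives 437 nM. Compound 2 `COc1cccc(Nc2nc(Nc3cc(C)[nH]n3)cc(N3CCN(C)CC3)n2)c1` gives 11300 nM, the higher of the two numbers, which makes compound 2 the weaker inhibitor of the pair. Compound 3 `Cc1cc(Nc2cc(N3CCN(C)CC3)nc(Nc3cccc(Cl)c3)n2)n[nH]1` differs from compound 2 in one place, with chloro in place of methoxy on an aromatic carbon, meta to a large group: chloro in place of methoxy on an aromatic carbon. In other words, 3-chlorophenyl replaces 3-methoxyphenyl. Among the compounds with values here, only one measured step bears on this change, and it is large: a 26-fold higher number from compound 1 to compound 2 (1.41 log units; beyond the scatter). That step exchanged 4-nitrophenyl for 3-methoxyphenyl, so it shows that the read-out can move widely when this aryl group changes, but it does not test chloro. Within the data shown here, no measured pair compares chloro with methoxy. A moderate move towards a lower number is therefore expected, smaller than the measured step and with wide uncertainty. The expected change is a 3.8-fold lower number from compound 2 to compound 3 (0.58 log units; beyond the scatter). The estimate for compound 3 is 3000 nM, with an expected range of 700 nM to 13000 nM.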

Compound 3, half-maximal inhibitory concentration: 2290 nM
Compound 3: middle estimate off by 1.3-fold (0.12 log units), on the high side; measured number inside the range.
By their numbers in this assay, from the lowest: compound 1; then compound 3; then compound 2.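

In this assay, within the data shown here, the exchange of methoxy for chloro gives a 4.9-fold lower number from compound 2 to compound 3 (0.69 log units; beyond the scatter), the first direct comparison of these two groups on an otherwise unchanged compound, and it shows that this single substituent alone moves the read-out beyond the scatter. Yet 3-chlorophenyl recovers only part of the gap to 4-nitrophenyl, as a 5.2-fold higher number from compound 1 to compound 3 (0.72 log units; beyond the scatter) shows, so compound 1 keeps the lowest number of the three, although this step changes both the group and its place on the ring and cannot separate the two. No measurement shown here accounts for the size of either step.

Going by these compounds, whether 3-nitrophenyl would match compound 1, or 4-chlorophenyl would match compound 3, remains open, so the contribution of the group cannot yet be told apart from that of its place on the ring. Also open, on these data alone, is how an amine, a carboxylic acid or a fluoro group would read on the same aromatic carbon, and whether the lower number seen with chloro extends to any other substituent there.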